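Terminal hydroxy to nonyl on the chain of compound 2

The source may report more compounds than this note shows. Statements on the series, on what has been measured and on what is new or still open speak of the compounds shown alone.

Compound 2 `Cc1c(N(C)C)nc(CCCCCCCCCCO)c(O)c1C` stands lowest of the three measured compounds in a functional assay on cells (Lymphocyte, Homo sapiens), read by trypan blue exclusion, with a stated time of 16 h, tested at 0.1 uM (a lower number here means a weaker effect, a higher number a stronger effect of the compound at the concentration tested), with 17%. Compound 1 `CCCCCCCCCCCCCCCCc1c(C)c(N(C)C)nc(C)c1O` gives 52% in this assay, and compound 3 `CCCCCCCCCCCCCCCCc1c(C)c(N2CCC2)nc(C)c1O` gives 58%. Among the compounds with values here, the only measured step that changes one place is a number 6 percentage points higher from compound 1 to compound 3 (within the scatter), which concerns the amine on an aromatic carbon and not the chain, so it does not bear on the present change. Compound 4 `CCCCCCCCCCCCCCCCCCCc1nc(N(C)C)c(C)c(C)c1O` differs from compound 2 by nonyl in place of hydroxy on a saturated chain carbon, ten or more bonds along the chain from an aromatic carbon. Within the data shown here, no measured pair shows this change by itself. Among the measured compounds shown here, what the numbers do show is that compound 1 and compound 3, each carrying a saturated chain without a hydroxy, sit well above compound 2, which is the one compound with a hydroxy at the end of its chain. On that footing compound 4 is expected to move toward the values of compound 1 and compound 3, and the expected step is a number 33 percentage points higher from compound 2 to compound 4 (beyond the scatter). Compound 4 is therefore estimated at 50%, within a range from 30% to 68%.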

Compound 4, a percentage reported as activity, at one concentration (the size of the read-out at that concentration, not a potency): 17%
For compound 4 the middle estimate is 33 percentage points above the measured one, outside the stated range (below it).
By their numbers in this assay, from the lowest: compounds 2 and 4 (each within the scatter of the next); then compounds 1 and 3 (each within the scatter of the next).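

At this position, on a saturated chain carbon, replacing hydroxy with nonyl in this assay gives no change at the digits printed from compound 2 to compound 4 (within the scatter). Within the data shown here, this is the first single-place reading of the chain end, and it shows no separation between the terminal hydroxy and the much larger nonyl group at this concentration. A chain end without a hydroxy is therefore not enough on its own to go with a higher number in this series, and compound 4 goes against any such pattern. Nothing available gives a reason for this result.

The compounds shown leave open how a terminal amine or a carboxylic acid at this chain end would read. Among these compounds, they also include no pair that separates chain length from where the chain sits on the shared core.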